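Moving the trifluoromethyl group within a diaryl urea

The source may hold more compounds than are shown below. What is called first, only, known or untested is meant among the compounds shown, and "the series" means these compounds.

Measured so far:
- compound 1, `COc1cc2cc(Oc3ccc(NC(=O)Nc4ccc(C)cc4)cc3)c(C)nc2cc1OC`: 111%
- compound 2, `COc1cc2cc(Oc3ccc(NC(=O)Nc4ccc(C(F)(F)F)cc4)cc3)c(C)nc2cc1OC`: 40.4%

Both compounds share one core and differ only in the group on the outer ring of the urea. In a functional assay on COLO 205 cells (Homo sapiens) for inhibition, read by sulforhodamine B assay, with a stated time of 48 h, tested at 10 uM (a higher number here means a weaker effect of the compound at the concentration tested, a lower number a stronger effect), compound 1 gives 111%, a number that shows no inhibition at the tested concentration. Compound 2 stands lowest of the two numbers, and the gap to compound 1 is beyond the scatter: a number 70.6 percentage points lower from compound 1 to compound 2 (beyond the scatter), a large step.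

Compound 3, `COc1cc2cc(Oc3ccc(NC(=O)Nc4cccc(C(F)(F)F)c4)cc3)c(C)nc2cc1OC`, has the same atoms as compound 2, joined differently: 3-(trifluoromethyl)phenyl in place of 4-(trifluoromethyl)phenyl on an amide-type nitrogen. For the measured compounds named here, no measured step covers a move of the trifluoromethyl group from one position of the ring to another; the one step available, from methyl to trifluoromethyl, speaks only to the nature of the group, not to where it sits. The expectation therefore rests on compound 2 alone, with wide uncertainty. A moderate weakening is expected, a number 21.6 percentage points higher from compound 2 to compound 3 (beyond the scatter), since positional changes of this kind often cost some effect, but the range must stay broad. For compound 3 the estimate in this assay is 62%, between 32% and 95%.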

Compound 3, a percentage reported as activity, at one concentration (the size of the read-out at that concentration, not a potency): -20.2%
Beside the measured number, compound 3's estimate is 82.2 percentage points above it; the whole stated range lies above it.
By their numbers in this assay, from the lowest: compound 3; then compound 2; then compound 1.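

Compound 2 and compound 3 contain the same atoms, so this pair isolates where the trifluoromethyl group sits rather than which group is present: 3-(trifluoromethyl)phenyl in place of 4-(trifluoromethyl)phenyl on the amide-type nitrogen gives in this assay a number a number 60.6 percentage points lower from compound 2 to compound 3 (beyond the scatter). The earlier step from methyl to trifluoromethyl showed only that the identity of the group matters, whereas this one shows that its placement on the outer ring can also produce a large change, and the full change on that nitrogen amounts to a number 131.2 percentage points lower from compound 1 to compound 3 (beyond the scatter). No evidence is available on the reason for this change.

The compounds shown leave open whether this gain belongs to the trifluoromethyl group itself or would also appear with another group placed the same way, as in 3-methylphenyl, 3-chlorophenyl or 3-methoxyphenyl. They also leave open whether a second substituent, such as a chlorine atom added to the 3-(trifluoromethyl)phenyl ring, would keep, strengthen or lose the effect seen with compound 3.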